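The source may hold more compounds than are shown below. What is called first, only, known or untested is meant among the compounds shown, and "the series" means these compounds.

Of the compounds shown here, three built on the same core have been tested in a functional assay on A549 cells (Homo sapiens) for cytotoxicity, read by MTT assay, with a stated time of 24 h (a lower number here means a stronger inhibitor, a higher number a weaker inhibitor), and a fourth awaits its result. Compound 1 `COc1ccccc1-n1cc(COc2c(/C=C\C(=O)O)ccc(OC)c2CC=C(C)C)nn1` gives 43000 nM in this assay, which is the higher of the two numbers recorded, although its nearest neighbour sits so close that no order can be read between them. That neighbour, compound 3 `COc1ccc(/C=C\C(=O)O)c(OCc2cn(-c3ccccc3)nn2)c1CC=C(C)C`, gives 40500 nM in this assay. Compound 2 `COc1ccc(/C=C\C(=O)O)c(OCc2cn(-c3ccccc3F)nn2)c1CC=C(C)C` belongs to the same set, but in this assay compound 2 gives "not determined" (no result reported), so it adds no number to the comparison.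

The step now in question leads from compound 1 to compound 4 `COc1ccc(/C=C\C(=O)O)c(OCc2cn(-c3ccc(C#N)cc3)nn2)c1CC=C(C)C`. The change is 4-cyanophenyl in place of 2-methoxyphenyl on an aromatic nitrogen. Within the data shown here, only one measured step speaks to it: a 1.1-fold lower number from compound 1 to compound 3 (0.03 log units; within the scatter), in which the methoxy group on the aromatic ring attached to the five-membered aromatic ring with three nitrogens was removed without any shift beyond the scatter. That step suggests the group on that ring nitrogen has little bearing on the number in this assay, though a nitrile in place of a methoxy group is a different change, and one step is a thin basis. On that evidence, compound 4 is expected to show a step of a 1.0-fold lower number from compound 1 to compound 4 (0.01 log units; within the scatter), which is no change beyond the scatter. The estimate for compound 4 in this assay is therefore 42000 nM, with a range from 18000 nM to 100000 nM.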

Compound 4, half-maximal inhibitory concentration: 42200 nM
Compound 4: middle estimate off by 1.0-fold (0.00 log units), on the low side, and the stated range covers the measured number.
By their numbers in this assay, from the lowest: compounds 3, 4 and 1 (each within the scatter of the next).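

In this assay, putting a nitrile on the phenyl ring gives a 1.0-fold higher number from compound 3 to compound 4 (0.02 log units; within the scatter), so this position now has an added group to set beside the removed methoxy group of the earlier step. Exchanging the whole aryl group on the ring nitrogen gives a 1.0-fold lower number from compound 1 to compound 4 (0.01 log units; within the scatter), which shows that replacing 2-methoxyphenyl with 4-cyanophenyl, a change of both the group and its place on the phenyl ring, also leaves the number within the scatter. Compounds 1, 3 and 4 therefore cannot be told apart here, and among these three the ring substituents tried make no measurable difference, while steps involving compound 2 cannot be read; nothing shown here accounts for this flat result.

From the compounds shown here alone, whether an amine on that phenyl ring, or a longer alkyl chain in place of the whole ring on the ring nitrogen, would move the number beyond the scatter remains open. The compounds shown also keep the rest of the shared core fixed, so they cannot tell whether this assay responds to changes elsewhere in the molecule.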